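Hydroxy to chloro at the para position of the ketone aryl

The compounds below may be only part of what the source reports. "The series", "measured", "known", "first", "only" and "open" are said of these compounds alone.

Among the compounds with values here, compound 2 `O=C(/C=C/c1cc2ccccc2[nH]c1=O)c1ccc(O)cc1` is the reference point in a functional assay on SN12C cells (Homo sapiens) for cytotoxicity, read by sulforhodamine B assay, with a stated time of 24 h (on this read-out lower numbers stand for stronger inhibition of growth and higher numbers for weaker inhibition of growth), where compound 2 gives 16000 nM, the only number in the set. Compound 1 `COc1ccc(C(=O)/C=C/c2cc3ccccc3[nH]c2=O)cc1` gives > 100000 nM in this assay, which is a limit and not a number (the limit of > 100000 nM in this assay, at which 1 of the 2 values shown sits). Within the data shown here, the one measured step, an at least 6.2-fold lower number from compound 1 to compound 2 (0.79 log units; beyond the scatter), concerns the same oxygen that is now removed: hydrogen in place of methyl on that oxygen.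

Compound 3 `O=C(/C=C/c1cc2ccccc2[nH]c1=O)c1ccc(Cl)cc1` is unmeasured. The change is chloro in place of hydroxy on an aromatic carbon, on an aromatic carbon of the six-membered aromatic ring of carbon only, para to a large group. Among the measured compounds shown here, only the step from compound 1 to compound 2 bears on it, and it was at least modest; since compound 3 lacks the hydroxy entirely, a step toward weaker growth inhibition is expected, with the limit in reach. Compound 3 is expected to give 60000 nM, between 15000 nM and 150000 nM. The expected step is a 3.8-fold higher number from compound 2 to compound 3 (0.57 log units; beyond the scatter).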

Compound 3, concentration for total growth inhibition: > 100000 nM
Compound 3 ended at the assay's limit; the forecaster's own chance of this, stated with the estimate: 40%; middle value at least 1.6-fold (0.22 log units) from the limit.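

In this assay, chloro in place of hydroxy on this aromatic carbon, para to a large group, gives an at least 6.2-fold higher number from compound 2 to compound 3 (0.79 log units; beyond the scatter). Methoxy and chloro are thus two different replacements of the hydroxy that both end at a limit of the assay. Compound 2, at 16000 nM, remains the only one of the three with a number. The step from compound 1 to compound 3 cannot be read, so methoxy and chloro cannot be ordered against each other: the limit of > 100000 nM in this assay, at which 2 of the 3 values shown sit.

As far as these compounds go, whether an amine or a carboxylic acid at this place would keep a number in this assay stays open. Also open, from the compounds shown here alone, is how much weaker compound 1 and compound 3 are than their limits show.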